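Swapping a propyl for a benzyl on a weak sulfonamide series

A few compounds are considered here, and "the series" means these few. Any claim that something is new, unique, unknown or untested is made for them only; others in the source may bear on it.

Three compounds share one core and differ only in what sits on a sulfonamide nitrogen. Compound 1 `CCCNS(=O)(=O)c1cncc(-c2ccn3nc(N)nc3c2)c1` carries a propyl there; in an assay on isolated protein for inhibition of phosphatidylinositol 4,5-bisphosphate 3-kinase catalytic subunit beta isoform (Homo sapiens) (on this read-out lower numbers stand for stronger inhibition and higher numbers for weaker inhibition), compound 1 gives 31600000 nM. Compound 2 `CC(C)NS(=O)(=O)c1cncc(-c2ccn3nc(N)nc3c2)c1` carries an isopropyl and gives 63100000 nM. Compound 3 `Nc1nc2cc(-c3cncc(S(N)(=O)=O)c3)ccn2n1` carries a hydrogen and gives 39800000 nM. Compound 1 has the lowest of the three numbers, but every step among them stays within the scatter: a 2.0-fold higher number from compound 1 to compound 2 (0.30 log units; within the scatter), a 1.3-fold higher number from compound 1 to compound 3 (0.10 log units; within the scatter) and a 1.6-fold lower number from compound 2 to compound 3 (0.20 log units; within the scatter). All three are very weak.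

Compound 4 `Nc1nc2cc(-c3cncc(S(=O)(=O)NCc4ccccc4)c3)ccn2n1` differs from compound 1 by phenyl in place of ethyl on a saturated chain carbon bound to a sulfonamide nitrogen. The measured steps all change the same sulfonamide nitrogen substituent and none moved the number beyond the scatter, so on this evidence a change there seems to matter little. Within the data shown here, a phenyl is a larger change than any tested, and no measured pair covers it, so the expectation rests only on the steady pattern already seen.

Compound 4 is therefore expected to give about 25000000 nM, within a range of 5000000 nM to 150000000 nM, which amounts to an expected 1.3-fold lower number from compound 1 to compound 4 (0.10 log units; within the scatter).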

Compound 4, half-maximal inhibitory concentration: 25100000 nM
Compound 4: the middle estimate sits 1.0-fold (0.00 log units) below what was measured, within the range that was stated.
By their numbers in this assay, from the lowest: compounds 4, 1, 3 and 2 (each within the scatter of the next, the first and the last beyond it).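

In this assay, an aromatic ring at the end of the group on this sulfonamide nitrogen does not shift the number beyond the scatter, either as phenyl in place of ethyl (a 1.3-fold lower number from compound 1 to compound 4 (0.10 log units; within the scatter)) or as benzyl in place of hydrogen (a 1.6-fold lower number from compound 3 to compound 4 (0.20 log units; within the scatter)). Benzyl in place of isopropyl (a 2.5-fold lower number from compound 2 to compound 4 (0.40 log units; beyond the scatter)) is the only step among these four compounds that passes the scatter, and it is a modest one. No measurement shown gives a reason for the size of these steps.

On these data alone, all four compounds remain very weak, so it is open whether any group at this nitrogen can move the number much further. A chain ending in an amine or a carboxylic acid might behave differently here, and changes to the shared core might matter more.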